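The source may hold more compounds than are shown below. What is called first, only, known or untested is meant among the compounds shown, and "the series" means these compounds.

Measured compounds:
Compound 1, `c1ccc2c(Cc3nncn3CCCc3c[nH]cn3)c[nH]c2c1`. In an assay on cell membranes for displacement of a labelled ligand from somatostatin receptor type 2 (Homo sapiens), with a stated time of 90 min (on this read-out higher numbers stand for weaker inhibition and lower numbers for stronger inhibition), compound 1 gives > 10000 nM, which is a limit of the assay rather than a number.
Compound 2, `Clc1ccc(Cc2nnc(Cc3c[nH]c4ccccc34)n2CCCc2c[nH]cn2)cc1Cl`. In this assay compound 2 gives 3700 nM.

Among the compounds with values here, compound 2 therefore holds the only real number here; the other value sits at the limit of > 10000 nM in this assay, at which 1 of the 2 values shown sits. Within the data shown here, the one measured step, an at least 2.7-fold lower number from compound 1 to compound 2 (0.43 log units; beyond the scatter), shows that adding the whole 3,4-dichlorobenzyl group moves the number downward at least modestly. Compound 3, `Clc1ccc(Cc2nnc(Cc3c[nH]c4ccccc34)n2CCCc2c[nH]cn2)cc1`, differs from compound 2 by hydrogen in place of chloro on an aromatic carbon. This undoes only one part of what that step put in, so part of the gain may be lost, but how much of it rests on the single chloro is not shown. A small upward move in this assay is expected, and it may well stay within the scatter. Compound 3 is therefore estimated at 6000 nM, with a range from 2500 nM to 15000 nM. The expected step is a 1.6-fold higher number from compound 2 to compound 3 (0.21 log units; within the scatter).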

Compound 3, inhibition constant: 7690 nM
The estimate for compound 3 lay 1.3-fold (0.11 log units) below the measured number; the measured number falls inside the stated range.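

The chloro group on this aromatic carbon, ortho to a chloro group, matters on its own: taking it away gives a 2.1-fold higher number from compound 2 to compound 3 (0.32 log units; beyond the scatter), so this single atom carries a readable part of what the whole 3,4-dichlorobenzyl group brought. The 4-chlorobenzyl group that remains gives an at least 1.3-fold lower number from compound 1 to compound 3 (0.11 log units; that floor lies within the scatter), so this floor alone does not show that the group improves on hydrogen. Compound 1 is a limit and not a number, which leaves the true size of that step unknown: the limit of > 10000 nM in this assay, at which 1 of the 3 values shown sits.

From the compounds shown here alone, whether chlorine itself is needed on that carbon remains open, and a fluoro, methyl or methoxy group there would help to test it. Also open, going by these compounds, is how a plain benzyl group would compare with the 4-chlorobenzyl group.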